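Aryl Swap on a Hydrazone Series: Compound 4 Forecast

A few compounds are considered here, and "the series" means these few. Any claim that something is new, unique, unknown or untested is made for them only; others in the source may bear on it.

Measured so far:
compound 1 `Cn1c(=O)c(=O)n(C2CCCC2)c2nc(N/N=C/c3ccc(C(F)(F)F)cc3)ncc21` — 29000 nM
compound 2 `Cn1c(=O)c(=O)n(C2CCCC2)c2nc(N/N=C/c3cc(C(F)(F)F)c(O)c(C(F)(F)F)c3)ncc21` — 27100 nM
compound 3 `Cn1c(=O)c(=O)n(C2CCCC2)c2nc(N/N=C/c3cccs3)ncc21` — 52600 nM

In a functional assay on HCT-116 cells (Homo sapiens) for antiproliferative activity, read by MTT assay (on this read-out lower numbers stand for stronger inhibition and higher numbers for weaker inhibition), compound 1 gives 29000 nM, compound 2 gives 27100 nM and compound 3 gives 52600 nM. The number for compound 3 is the largest of the three, yet its gap to compound 1 and its gap to compound 2 both fall within the scatter, so the three compounds cannot be separated on these data.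

Compound 4 `Cn1c(=O)c(=O)n(C2CCCC2)c2nc(N/N=C/c3cc([N+](=O)[O-])ccc3Cl)ncc21` is not yet measured. Relative to compound 3 the change is 2-chloro-5-nitrophenyl in place of thiophen-2-yl on a carbon with a double bond to nitrogen. Among the measured compounds shown here, the one measured step that bears on this position is a 1.8-fold higher number from compound 1 to compound 3 (0.26 log units; within the scatter), a swap of one aromatic group for another on the same carbon that stayed within the scatter. Compound 1 and compound 2, which differ only in the substituents on the phenyl ring, likewise show values within the scatter of one another. Nothing here suggests that the identity of the aromatic group moves the read-out beyond the scatter.

Compound 4 is therefore expected to show a 1.5-fold lower number from compound 3 to compound 4 (0.18 log units; within the scatter), no shift beyond the scatter. The estimate for compound 4 is 35000 nM, within a range of 15000 nM to 80000 nM.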

Compound 4, half-maximal inhibitory concentration: 5610 nM
Compound 4: the middle estimate sits 6.2-fold (0.80 log units) above what was measured; measured number outside the range, below it.
By their numbers in this assay, from the lowest: compound 4; then compounds 2, 1 and 3 (each within the scatter of the next).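

In this assay, the place on a carbon with a double bond to nitrogen proves able to move the read-out beyond the scatter: 2-chloro-5-nitrophenyl gives a 9.4-fold lower number from compound 3 to compound 4 (0.97 log units; beyond the scatter) against thiophen-2-yl and a 5.2-fold lower number from compound 1 to compound 4 (0.71 log units; beyond the scatter) against 4-(trifluoromethyl)phenyl. The earlier swap at this place, a 1.8-fold higher number from compound 1 to compound 3 (0.26 log units; within the scatter), had stayed within the scatter, so the aromatic groups there are not interchangeable, and a change of aromatic group alone can separate compounds that the first three values could not. No measurement shown explains why this group lowers the number.

The 2-chloro-5-nitrophenyl group enters as a single change and no compound shown carries the chlorine or the nitro group alone on the phenyl ring, so it stays open which of the two, or whether only the pair, goes with the lower number. It is also open whether the lower number would survive with an amine or a carboxylic acid in place of the nitro group, as the compounds shown hold neither.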